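Methylphenyl isomers on the shared core: outlook for compound 3

This account rests on a few compounds, and the source may have more. Where it says the series, first, only, none or still open, it means among the compounds named here.

Two compounds of the series have numbers in a physicochemical assay for solubility, read by spectrophotometry, in phosphate buffer, with a stated time of 18 h, at pH 7.4; on this read-out lower numbers stand for lower solubility and higher numbers for higher solubility. Compound 1 (`CCc1ccc(-c2nc3c(c(C)nn3-c3ccccc3C)c(-c3ccccc3O)c2C#N)cc1`) gives 9600 nM, and compound 2 (`CCc1ccc(-c2nc3c(c(C)nn3-c3cccc(C)c3)c(-c3ccccc3O)c2C#N)cc1`) gives 4800 nM. These two values lie within the scatter of each other, so compound 2 has no distinct standing against compound 1. The next compound is compound 3 (`CCc1ccc(-c2nc3c(c(C)nn3-c3ccc(C)cc3)c(-c3ccccc3O)c2C#N)cc1`), which carries 4-methylphenyl in place of 3-methylphenyl on an aromatic nitrogen of the shared core: 4-methylphenyl in place of 3-methylphenyl on an aromatic nitrogen. The two compounds have the same atoms, joined differently. For the measured compounds named here, the only measured step that bears on this change is a 2.0-fold lower number from compound 1 to compound 2 (0.30 log units; within the scatter), where 3-methylphenyl took the place of 2-methylphenyl on that aromatic nitrogen. Going by the values given here, that is a single step, and no compound with 4-methylphenyl has a measured number yet. No shift beyond the scatter is therefore expected in this assay, and no firm direction can be assigned. The expected step is a 1.1-fold higher number from compound 2 to compound 3 (0.06 log units; within the scatter). For compound 3 the estimated value is 5500 nM, with an expected range of 2400 nM to 12000 nM.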

Compound 3, solubility: 8900 nM
Compound 3: middle estimate off by 1.6-fold (0.21 log units), on the low side; low and high end bracket the measured number.
By their numbers in this assay, from the lowest: compounds 2, 3 and 1 (each within the scatter of the next).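

In this assay, the third methylphenyl isomer completes the set at this position on the aromatic nitrogen of the shared core. Putting 4-methylphenyl in place of 3-methylphenyl gives a 1.9-fold higher number from compound 2 to compound 3 (0.27 log units; within the scatter), and putting 4-methylphenyl in place of 2-methylphenyl gives a 1.1-fold lower number from compound 1 to compound 3 (0.03 log units; within the scatter); together with the earlier step, this means that all three pairs of isomers now lie within the scatter, so moving the methyl group around this phenyl ring does not separate any of the three compounds on this read-out. No supporting data bear on why these three numbers fall where they do.

From the compounds shown here alone, it remains open whether a group other than methyl on this phenyl ring, such as an amine, a carboxylic acid or a longer chain like propyl, would give a step beyond the scatter in this assay. Going by these compounds, it is also open whether the isomers would stay this close with a change elsewhere on the shared core, since all three compounds share every other part of the structure.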